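The compounds below may be only part of what the source reports. "The series", "measured", "known", "first", "only" and "open" are said of these compounds alone.

Compound 1 `Cc1ccc(N2CCN(S(=O)(=O)c3ccc4c(c3)CC(=O)N4)CC2)cc1` shares its core with compound 2 `N#Cc1ccc(N2CCN(S(=O)(=O)c3ccc4c(c3)CC(=O)N4)CC2)cc1`, and the two differ only in the group carried by the outer aromatic ring: a methyl in compound 1, a nitrile in compound 2. In an assay on isolated protein for inhibition of lysosomal alpha-glucosidase (Homo sapiens), read by fluorescence, with stated times of 5 min and 45 min (on this read-out higher numbers stand for weaker inhibition and lower numbers for stronger inhibition), compound 1 is reported as "not active" (no number reported), so no single number stands for it, only the statement that no measurable inhibition was seen. Compound 2, by contrast, gives 2910 nM in this assay, a weak but measurable inhibition. Compound 3 `O=C1Cc2cc(S(=O)(=O)N3CCN(c4ccc(Cl)cc4)CC3)ccc2N1` has not yet been tested in this assay. It differs from compound 1 in one place (chloro in place of methyl on an aromatic carbon). Since compound 1 carries no number, the size of this step in this assay cannot be read off; the expectation is a gain in inhibition, enough to bring compound 3 into the measurable range where compound 2 sits, though a result with no number remains possible. On that basis the estimate for compound 3 in this assay is 5000 nM, expected to fall between 1500 nM and 20000 nM.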

Compound 3, half-maximal inhibitory concentration: 94300 nM
The estimate for compound 3 lay 19-fold (1.28 log units) below the measured number; the whole stated range lies below it.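

In this assay the group at this position, para to a large group, clearly matters, even though the change touches a single small substituent: putting chloro in place of nitrile gives a 32-fold higher number from compound 2 to compound 3 (1.51 log units; beyond the scatter) and leaves compound 3 a very weak inhibitor. Chloro still gives a number on the scale, whereas compound 1, with methyl in the same place, is reported as "not active" (no number reported) and so the steps to and from compound 1 cannot be read, although a measurable value for chloro does set compound 3 apart from that result. Nothing shown here offers any measured explanation for why these groups differ so much.

As far as these compounds go, three compounds give only a narrow view of this position, so it stays open how an amine, a carboxylic acid, a methoxy group or a plain hydrogen in the same place would compare with nitrile and chloro. From the compounds shown here alone, it also stays open whether the large step between nitrile and chloro would look the same on a different core.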